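A few compounds are considered here, and "the series" means these few. Any claim that something is new, unique, unknown or untested is made for them only; others in the source may bear on it.

Compound 2 `C=C(Br)C(=O)Nc1cccc(-c2cn3nc(CCc4ccccc4)sc3n2)c1` gives 4200 nM in a functional assay on CCRF-CEM cells (Homo sapiens) for inhibition, read by cell counting, with a stated time of 3 days; on this read-out lower numbers stand for stronger inhibition and higher numbers for weaker inhibition. Going by the values given here, its number is the higher of the two recorded, but the gap to its only neighbour is small: compound 1 `C=C(Br)C(=O)Nc1cccc(-c2cn3nc(Cc4cccc(OC)c4)sc3n2)c1` gives 3100 nM in this assay, and the one measured step, a 1.4-fold higher number from compound 1 to compound 2 (0.13 log units; within the scatter), sits inside the scatter, so the exchange of 3-methoxyphenyl for benzyl on a saturated chain carbon bound to an aromatic carbon left no trace that can be read. Compound 3 `C=C(Br)C(=O)Nc1cccc(-c2cn3nc(Cc4ccc(OC)cc4)sc3n2)c1` has not yet been measured. It differs from compound 2 by 4-methoxyphenyl in place of benzyl on a saturated chain carbon bound to an aromatic carbon. This is the same kind of exchange as the measured one, run the other way, with the distinction that compound 1 carried 3-methoxyphenyl where compound 3 carries 4-methoxyphenyl. Because a 1.4-fold higher number from compound 1 to compound 2 (0.13 log units; within the scatter) stayed within the scatter when a methoxyphenyl group and benzyl were traded at that carbon, compound 3 is expected to show no step beyond the scatter in this assay, a 1.2-fold lower number from compound 2 to compound 3 (0.08 log units; within the scatter). Among the compounds with values here, the estimate for compound 3 is therefore 3500 nM, with a range from 1200 nM to 10000 nM, the wider spread reflecting that only a single step informs it.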

Compound 3, half-maximal inhibitory concentration: 2300 nM
The estimate for compound 3 lay 1.5-fold (0.18 log units) above the measured number, within the range that was stated.
By their numbers in this assay, from the lowest: compounds 3, 1 and 2 (each within the scatter of the next).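

Going by these compounds alone, for the first time, a methoxyphenyl group and the benzyl it replaces can be set against a second methoxyphenyl partner at this place: in this assay, 4-methoxyphenyl in place of benzyl on a saturated chain carbon bound to an aromatic carbon gives a 1.8-fold lower number from compound 2 to compound 3 (0.26 log units; within the scatter), so this exchange, like the earlier one with 3-methoxyphenyl, cannot be read as a real change. Within the data shown here, the new compound also gives the first direct comparison of the two methoxyphenyl groups, and a 1.3-fold lower number from compound 1 to compound 3 (0.13 log units; within the scatter) shows that the assay does not separate 4-methoxyphenyl from 3-methoxyphenyl, so all three groups at this carbon remain indistinguishable on this read-out. No other measurement accompanies these numbers, and nothing shown offers an explanation for them.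

The compounds shown leave open whether an amine or a carboxylic acid in place of the methoxy group, or a chain longer than phenethyl, would give a step beyond the scatter in this assay. As far as these compounds go, all three compounds also share the same core and the same bromine-bearing amide, so how a change in those parts would read remains open.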